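A Methyl Added to the Piperidine Ring of Compound 1

The source may report more compounds than this note shows. Statements on the series, on what has been measured and on what is new or still open speak of the compounds shown alone.

For the measured compounds named here, compound 1 `Cc1nc(Nc2ccc3sc(C(=O)Nc4c(C)cccc4Cl)cc3c2)cc(N2CCCCC2)n1` is the weakest of the three compounds measured so far: in a functional assay on K562 cells (Homo sapiens) for inhibition, read by MTT assay and WST assay, with a stated time of 72 h, tested at 10 uM (a higher number here means more inhibition of growth at the concentration tested, a lower number less inhibition of growth), compound 1 gives 8.78%. The two other compounds share the amide side of compound 1 but carry a different core. Compound 2 `COc1cc2c(Nc3ccc4sc(C(=O)Nc5c(C)cccc5Cl)cc4c3)ncnc2cc1OCCCN1CCCCC1C` gives 84.2%, and compound 3 `CCN(CC)CCCOc1cc2ncnc(Nc3ccc4sc(C(=O)Nc5c(C)cccc5Cl)cc4c3)c2cc1OC` gives 72.5%. The gap between compound 1 and each of them lies well beyond the scatter, so compound 1 stands clearly lowest.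

Compound 4 `Cc1nc(Nc2ccc3sc(C(=O)Nc4c(C)cccc4Cl)cc3c2)cc(N2CCC(C)CC2)n1` differs from compound 1 in one place: methyl in place of hydrogen on a saturated ring carbon. Going by the values given here, the only measured step that alters a saturated amine, a number 11.7 percentage points lower from compound 2 to compound 3 (beyond the scatter), sits on the other core and swaps one amine for another rather than adding a methyl to a ring. It shows that such a change within this set can move the number by a modest amount, but it says nothing direct about a methyl on the piperidine of compound 1. Among the compounds with values here, no measured step bears directly on this change, so the expectation is that compound 4 stays close to compound 1. Compound 4 is therefore expected to show a number 3.2 percentage points higher from compound 1 to compound 4 (within the scatter), a step not expected to go beyond the scatter. The estimate for compound 4 in this assay is 12%, within a range from 0% to 35%.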

Compound 4, percent growth inhibition at one concentration: 20.5%
The estimate for compound 4 lay 8.5 percentage points below the measured number; measured number inside the range.
By their numbers in this assay, from the lowest: compound 1; then compound 4; then compound 3; then compound 2.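

In this assay the methyl gives a number 11.7 percentage points higher from compound 1 to compound 4 (beyond the scatter) and so shows that the piperidine ring of compound 1 is not indifferent to change: one added carbon, three ring bonds from the ring nitrogen, is enough to move the number past the usual scatter. For the compounds shown here, the only earlier step on a saturated amine swapped one amine for another on a different core, whereas this step alters the ring itself on the core of compound 1 and goes with more inhibition of growth at the concentration tested. No evidence at hand gives a cause for this step.

On these data alone, it remains open whether the rise belongs to methyl in particular or would also come with another group on this same ring carbon, such as ethyl, a hydroxyl group or a primary amine. As far as these compounds go, it also remains open how far the number would move if a morpholine ring stood in place of the whole 4-methylpiperidin-1-yl group on the core of compound 4.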